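The source may report more compounds than this note shows. Statements on the series, on what has been measured and on what is new or still open speak of the compounds shown alone.

Compound 1 `NCC[C@H]1CCC[C@@H](c2ccccc2)C1` gives 138 nM in an assay on membranes from brain for displacement of a labelled ligand from Sigma non-opioid intracellular receptor 1 (Cavia porcellus), read by scintillation counting, with a stated time of 120 min; on this read-out higher numbers stand for weaker inhibition and lower numbers for stronger inhibition. Compound 2 `NCC[C@H]1CCC[C@H](c2ccccc2)C1` gives 603 nM in this assay, the higher of the two numbers shown, and a 4.4-fold higher number from compound 1 to compound 2 (0.64 log units; beyond the scatter) rests on configuration alone (the fact that compounds 1 and 2 differ only in the configuration as drawn). Compound 3 `NCC[C@@H]1CCC[C@@H](c2ccccc2)C1` differs from compound 2 as follows: the two compounds have the same atoms and bonds and differ only in configuration as drawn: 2 of 2 stereo elements differ (all stereocentres are inverted: mirror images); a stereocentre at a saturated ring carbon is drawn S in compound 2 and R in compound 3; a stereocentre at a saturated ring carbon is drawn S in compound 2 and R in compound 3. No measured step compares mirror images; the one step shown, a 4.4-fold higher number from compound 1 to compound 2 (0.64 log units; beyond the scatter), concerns a single stereocentre, so it indicates only the size a configurational change can reach, not its direction here. For compound 3 the expected step is a 2.0-fold lower number from compound 2 to compound 3 (0.30 log units; within the scatter), with wide uncertainty. Compound 3 is therefore estimated at 300 nM, range 60 nM to 1500 nM.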

Compound 3, inhibition constant: 43 nM
For compound 3 the middle estimate is 7.0-fold (0.84 log units) above the measured one, and the stated range ends above it.
By their numbers in this assay, from the lowest: compound 3; then compound 1; then compound 2.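

Full inversion is a large step in this assay, a 14-fold lower number from compound 2 to compound 3 (1.15 log units; beyond the scatter), so this mirror-image pair is clearly separated. Changing a single stereocentre, a different one from that changed between compounds 1 and 2, also gives a step beyond the scatter, a 3.2-fold lower number from compound 1 to compound 3 (0.51 log units; beyond the scatter), so compound 3 holds the lowest number of the three. These differences rest on configuration alone: the fact that compounds 2 and 3 differ only in the configuration as drawn

Still open, from the compounds shown here alone, are the fourth arrangement of the two stereocentres and whether this order holds with a tertiary amine or a longer chain.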